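The source may report more compounds than this note shows. Statements on the series, on what has been measured and on what is new or still open speak of the compounds shown alone.

Compound 3, whose structure is `Cc1nc(NCCOC(C)C)nc(N[C@@H]2C[C@H](CO)[C@@H](O)[C@H]2O)c1-c1nc2ccccc2s1`, gives the highest number of the three compounds measured in an ADME assay on the whole organism (plasma) for pharmacokinetics, with Rattus norvegicus as the target, with a stated time of 6 h, at a dose of 10 mg/kg by the oral route (a lower number here means less compound in the circulation, a higher number more compound in the circulation at the dose given), namely 426 ng.h/mL. The compound nearest to it is compound 2, `Nc1ncc(-c2nc3ccccc3s2)c(N[C@@H]2C[C@H](CO)[C@@H](O)[C@H]2O)n1`, which in this assay gives 149 ng.h/mL. Furthest away is compound 1, `Nc1nc(Cl)c(-c2nc3ccccc3s2)c(N[C@@H]2C[C@H](CO)[C@@H](O)[C@H]2O)n1`, which in this assay gives 32.6 ng.h/mL. Among the measured compounds shown here, the only step between two measured compounds that differ in one place is the one in which hydrogen replaces chloro on an aromatic carbon, and it gives a 4.6-fold higher number from compound 1 to compound 2 (0.66 log units; beyond the scatter).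

Compound 4, `Cc1nc(NCc2cccnc2)nc(N[C@@H]2C[C@H](CO)[C@@H](O)[C@H]2O)c1-c1nc2ccccc2s1`, is not yet measured. It differs from compound 3 in one place: pyridin-3-yl in place of isopropoxymethyl on a saturated chain carbon bound to a nitrogen on an aromatic ring. For the measured compounds named here, no measured step touches this part of the molecule, since the step from compound 1 to compound 2 concerns an aromatic carbon on the core rather than the chain on the ring nitrogen, so it offers no direct guide to the size or direction of the change here. In the absence of a comparable step, compound 4 is expected to stay close to compound 3, with a 1.4-fold lower number from compound 3 to compound 4 (0.15 log units; within the scatter) as the estimated step. Compound 4 is therefore estimated at 300 ng.h/mL in this assay, within a wide range from 80 ng.h/mL to 1200 ng.h/mL.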

Compound 4, area under the concentration-time curve: 9.57 ng.h/mL
Beside the measured number, compound 4's estimate is 31-fold (1.50 log units) above it; the whole stated range lies above it.
By their numbers in this assay, from the lowest: compound 4; then compound 1; then compound 2; then compound 3.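

In this assay, replacing the 2-isopropoxyethyl chain of compound 3 with the (pyridin-3-yl)methyl group of compound 4 gives a 45-fold lower number from compound 3 to compound 4 (1.65 log units; beyond the scatter). Among the compounds shown here, until now, the only change that could be read on its own was on an aromatic carbon of the core, so this step is the first to show that the group on the amino nitrogen can also strongly affect how much compound reaches the circulation, even with the rest of the molecule unchanged. Nothing available explains the drop, and the read-out itself cannot separate how much compound is taken up from how quickly it is removed.

With only these two groups to compare at this position, the step cannot be assigned to the arrival of the aromatic ring, the loss of the isopropoxy ether, or the change in chain length, and a benzyl group or a 2-(pyridin-3-yl)ethyl chain would help to tell these apart. Going by these compounds, it also remains open whether the same swap would have a similar effect on the core of compound 2, which carries hydrogen and a free amino group where compound 3 carries methyl and the substituted amino group.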